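Swapping a Nitro for a Methyl on a Urea Analogue

The source may hold more compounds than are shown below. What is called first, only, known or untested is meant among the compounds shown, and "the series" means these compounds.

Four compounds sharing a common core were studied in an assay on SK-N-MC cells for inhibition of Neuropeptide Y receptor type 1 (Homo sapiens); a lower number here means a stronger inhibitor, a higher number a weaker inhibitor. Compound 1 `COC(=O)C1=C(C)N=C(C)/C(=C(/O)OC)C1c1cccc(N/C(=N/CCNC2CCN(c3ccccc3[N+](=O)[O-])CC2)NC#N)c1` gives 4 nM in this assay. Compound 2 `COC(=O)C1=C(C)N=C(C)/C(=C(/O)OC)C1c1cccc(N/C(=N/CCNC2CCN(c3ccccc3C)CC2)NC#N)c1` gives 4 nM. The two differ in a single place: methyl in place of nitro on an aromatic carbon The measured outcome of that change is no change at the digits printed from compound 1 to compound 2 (within the scatter), so the two values sit within the usual scatter of each other and cannot be told apart.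

Compound 3 `COC(=O)C1=C(C)N=C(C)/C(=C(/O)OC)C1c1cccc(NC(=O)NCCNC2CCN(c3ccccc3[N+](=O)[O-])CC2)c1` carries the same nitro-bearing ring as compound 1 but differs from it elsewhere in the molecule; how the two cores differ is not broken down here. In this assay compound 3 gives 2 nM. This number stands within the scatter of both compound 1 and compound 2, so no order among the three can be claimed.

Compound 4 `COC(=O)C1=C(C)N=C(C)/C(=C(/O)OC)C1c1cccc(NC(=O)NCCNC2CCN(c3ccccc3C)CC2)c1` has not yet been measured. It is made from compound 3 by one change: methyl in place of nitro on an aromatic carbon The place of this change is described in the same words as for the change from compound 1 to compound 2, so it is the same change applied to a different core. Because no change at the digits printed from compound 1 to compound 2 (within the scatter), the expected step from compound 3 to compound 4 is no change at the digits printed from compound 3 to compound 4 (within the scatter), which is likewise expected to stay within the scatter. On that basis compound 4 is estimated to give 2 nM in this assay, with an expected range from 0.8 nM to 6 nM.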

Compound 4, half-maximal inhibitory concentration: 4 nM
Compound 4: the middle estimate sits 2.0-fold (0.30 log units) below what was measured, and the stated range covers the measured number.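

In this assay, swapping nitro for methyl on the second core gives a 2.0-fold higher number from compound 3 to compound 4 (0.30 log units; within the scatter). Set beside the same swap on the first core, the two outcomes cannot be told apart: the same change on two cores in this assay, no change at the digits printed (within the scatter) from compound 1 to compound 2 and a 2.0-fold higher number (0.30 log units; within the scatter) from compound 3 to compound 4, 2.0-fold (0.30 log units) apart, within the scatter of two such steps. This shows that the change behaves alike on these two cores, with neither step large enough to separate from ordinary repeat-to-repeat variation; it does not show that nitro and methyl are interchangeable across the series, since two pairs are a small sample, and it cannot reveal any small effect of the swap or any small difference between the cores that lies inside the scatter.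

The compounds shown carry only 2-nitrophenyl and 2-methylphenyl at this place, so it remains open how a chlorine atom, a methoxy group, an amine or a carboxylic acid in the same position would behave on either core. Also open is whether any group is needed there at all, as a plain phenyl ring with only hydrogen in that place is not among the compounds shown.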